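From 3-aminopropyl to 2-aminoethoxy in compound 4

A few compounds are considered here, and "the series" means these few. Any claim that something is new, unique, unknown or untested is made for them only; others in the source may bear on it.

Compound 1 `CC(C)=CCC/C(C)=C/CC/C(C)=C/CSc1ccccc1C(=O)NCCN` gives > 50000 nM
Compound 2 `CC(C)=CCC/C(C)=C/CC/C(C)=C/CSc1ccccc1C(=O)NCCCN` gives 11800 nM
Compound 3 `CC(C)=CCC/C(C)=C/CC/C(C)=C/CSc1ccccc1C(=O)NCCCCCN` gives 7560 nM

These values come from a functional assay on PANC-1 cells (Homo sapiens) for cytotoxicity, read by MTT assay, with a stated time of 48 h (a higher number here means a weaker inhibitor, a lower number a stronger inhibitor), and the three compounds differ only in the length of one chain. The entry for compound 1 > 50000 nM is a limit of the assay and not a number. Compound 3 stands level with compound 2 within the scatter (a 1.6-fold lower number from compound 2 to compound 3 (0.19 log units; within the scatter)).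

In compound 4 `CC(C)=CCC/C(C)=C/CC/C(C)=C/CSc1ccccc1C(=O)NCCOCCN` the chain changes in a different way: 2-aminoethoxy sits in place of 3-aminopropyl on a saturated chain carbon, two bonds along the chain from an amide-type nitrogen (2-aminoethoxy in place of 3-aminopropyl on a saturated chain carbon, two bonds along the chain from an amide-type nitrogen).

Two measured steps lie beyond the scatter (an at least 4.2-fold lower number from compound 1 to compound 2 (0.62 log units; beyond the scatter) and an at least 6.6-fold lower number from compound 1 to compound 3 (0.82 log units; beyond the scatter)), and both lengthen the chain of compound 1. The closest comparison, the step from compound 2 to compound 3 (a 1.6-fold lower number from compound 2 to compound 3 (0.19 log units; within the scatter)), stayed within the scatter. Going by the values given here, no measured step puts an oxygen into this chain, so the forecast is uncertain. No step beyond the scatter is expected in this assay for this swap. The expected change is small (a 1.3-fold higher number from compound 3 to compound 4 (0.12 log units; within the scatter)). For compound 4 the estimated value is 10000 nM with an expected range from 5000 nM to 22000 nM as its limits.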

Compound 4, half-maximal inhibitory concentration in the PANC-1 assay: 3780 nM
Beside the measured number, compound 4's estimate is 2.6-fold (0.42 log units) above it; the measured number lies below the stated range.
By their numbers in the PANC-1 assay, from the lowest: compounds 4, 3 and 2 (each within the scatter of the next, the first and the last beyond it). At a limit, above all of these: compound 1.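

Swapping 3-aminopropyl for 2-aminoethoxy keeps the count of heavy atoms the same and puts an oxygen in the chain, and in the PANC-1 assay this swap leaves cytotoxicity level, with a 2.0-fold lower number from compound 3 to compound 4 (0.30 log units; within the scatter). In a physicochemical assay for lipophilicity (a higher number here means a more lipophilic compound, a lower number a more polar compound), however, compound 3 gives 5.98 and compound 4 gives 4.85, so the same swap clearly separates the two compounds, and a large difference in lipophilicity comes without a matching difference in cytotoxicity: the measured partition coefficient of compound 3, 5.98, and of compound 4, 4.85, a number 1.13 log units lower (beyond the scatter). In the PANC-1 assay the 2-aminoethoxy chain also stands clear of the shorter chains, with a 3.1-fold lower number from compound 2 to compound 4 (0.49 log units; beyond the scatter) and an at least 13-fold lower number from compound 1 to compound 4 (1.12 log units; beyond the scatter), the last of these resting on a limit of the assay for compound 1.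

The compounds shown leave open whether a longer chain carrying a second ether oxygen would keep this level of cytotoxicity. They also leave open whether a carboxylic acid or a hydroxyl could replace the amine at the chain end.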